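Swapping Hydroxy for Chloro on One Aromatic Carbon

A few compounds are considered here, and "the series" means these few. Any claim that something is new, unique, unknown or untested is made for them only; others in the source may bear on it.

In a functional assay on LNCaP cells (Homo sapiens) for antiproliferative activity, read by MTT assay, with a stated time of 24 h (a lower number here means a stronger inhibitor, a higher number a weaker inhibitor), compound 3 `COc1ccc(-c2noc(-c3ccc(O)cc3)n2)cc1OC1CCCC1` gives 860 nM. That is clearly weaker than compound 2 `COc1ccc(-c2noc(C3CCNCC3)n2)cc1OC1CCCC1`, which gives 10 nM. Compound 1 `COc1ccc(-c2noc(-c3ccncc3)n2)cc1OC1CCCC1` is reported only as a limit of the assay, > 1000000 nM.

Compound 4 `COc1ccc(-c2noc(-c3ccc(Cl)cc3)n2)cc1OC1CCCC1` differs from compound 3 in one place: chloro in place of hydroxy on an aromatic carbon. Among the measured compounds shown here, no measured step makes this exact swap. The closest steps replace the whole group, and both are large: an at least 1100-fold lower number from compound 1 to compound 3 (3.06 log units; beyond the scatter) and an 86-fold higher number from compound 2 to compound 3 (1.93 log units; beyond the scatter). They show that this group matters, but give no direction for so small a swap. The best expectation is therefore no clear shift, an estimated 1.2-fold higher number from compound 3 to compound 4 (0.07 log units; within the scatter). Compound 4 is expected at 1000 nM, within an estimated range of 100 nM to 10000 nM.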

Compound 4, half-maximal inhibitory concentration: 20800 nM
For compound 4 the middle estimate is 21-fold (1.32 log units) below the measured one; measured number above the stated range.
By their numbers in this assay, from the lowest: compound 2; then compound 3; then compound 4. At a limit, above all of these: compound 1.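

In this assay, even a swap of one heavy atom on this aromatic carbon counts: chloro in place of hydroxy gives a 24-fold higher number from compound 3 to compound 4 (1.38 log units; beyond the scatter). The 4-chlorophenyl group also falls far behind piperidin-4-yl, with a 2100-fold higher number from compound 2 to compound 4 (3.32 log units; beyond the scatter). Against pyridin-4-yl it still comes out ahead, with an at least 48-fold lower number from compound 1 to compound 4 (1.68 log units; beyond the scatter), but that step rests on a limit and not on a measured number: the limit of > 1000000 nM in this assay, at which 1 of the 4 values shown sits.

Going by these compounds, how an amine or a carboxylic acid on this same carbon would compare with hydroxy and chloro remains open.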